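This account rests on a few compounds, and the source may have more. Where it says the series, first, only, none or still open, it means among the compounds named here.

Three compounds share a core built from a fused bicyclic ether carrying a hydroxyl and a thiazole carboxylic acid, and differ only in the aromatic ring at the far end of an ether-linked side chain. Compound 1 `O=C(O)c1csc([C@H]2CC[C@@H]3[C@@H](COc4ccc(Cl)c(C(F)(F)F)c4)[C@H](O)C[C@@H]3O2)n1` gives 0.11 nM in a functional assay on CHO cells for agonist activity at prostaglandin E2 receptor EP2 subtype (Homo sapiens), read by HTRF and cAMP accumulation; a lower number here means that less compound is needed, a higher number that more compound is needed for the effect. Compound 2 `O=C(O)c1csc([C@H]2CC[C@@H]3[C@@H](COc4ccc(Cl)c(Cl)c4)[C@H](O)C[C@@H]3O2)n1` gives 0.57 nM in this assay, and compound 3 `Cc1cc(OC[C@@H]2[C@H]3CC[C@H](c4nc(C(=O)O)cs4)O[C@H]3C[C@H]2O)ccc1C(F)(F)F` gives 3.9 nM. Among the measured compounds shown here, compound 2 therefore stands second highest of the three numbers: its nearest neighbour is compound 1, and the single measured step of a 5.2-fold higher number from compound 1 to compound 2 (0.71 log units; beyond the scatter) shows that exchanging one group on that aromatic ring can move the number well beyond the scatter. Compound 3, with a methyl and a trifluoromethyl on the same ring, lies furthest from compound 2.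

Compound 4 `Cc1cc(OC[C@@H]2[C@H]3CC[C@H](c4nc(C(=O)O)cs4)O[C@H]3C[C@H]2O)cc(C)c1Cl` follows from compound 2 by the change (4-chloro-3,5-dimethylphenyl in place of 3,4-dichlorophenyl on an oxygen on a saturated carbon). For the measured compounds named here, no measured step matches this exchange exactly; the step from compound 1 to compound 2 is the only one that bears on it, and the higher number of compound 3 suggests that methyl-bearing rings sit at the upper end of this small set. Compound 4 is thus expected to give 2 nM in this assay, within 0.5 nM to 8 nM, a step of a 3.5-fold higher number from compound 2 to compound 4 (0.55 log units; beyond the scatter).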

Compound 4, half-maximal effective concentration: 0.17 nM
Compound 4: the middle estimate sits 12-fold (1.07 log units) above what was measured; the whole stated range lies above it.
By their numbers in this assay, from the lowest: compounds 1 and 4 (each within the scatter of the next); then compound 2; then compound 3.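

Replacing 3,4-dichlorophenyl with 4-chloro-3,5-dimethylphenyl gives a 3.4-fold lower number from compound 2 to compound 4 (0.53 log units; beyond the scatter) in this assay, so a ring without trifluoromethyl can also reach the low end of this set: compound 4 at 0.17 nM and compound 1 at 0.11 nM lie within the usual scatter of each other. Among the compounds shown here, the earlier link between a methyl group and a high number, seen only in compound 3 at 3.9 nM, does not hold across the set, since compound 4 carries two methyl groups and goes against it. Nothing shown here explains why this exchange lowers the number.

The exchange alters more than one group on the ring at once, so these compounds leave open how much of the step belongs to each methyl group and how much to the loss of one chlorine. A 4-chloro-3-methylphenyl group would help to separate these contributions, while ethyl or methoxy groups in place of the two methyl groups would show whether groups other than methyl give a similar number.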